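The compounds below may be only part of what the source reports. "The series", "measured", "known", "first", "only" and "open" are said of these compounds alone.

Compound 3 `COc1ccc(-c2nnc(SCC(=O)Nc3ccc(/C(C)=N/O)cc3)n2-c2ccccc2)cc1OC` sits at 57% in a functional assay on the whole organism (strain albino) for inhibition, with Rattus norvegicus as the target, read by paw edema, with stated times of 30 min and 1 h, at a dose of 0.28 mmol/kg by the oral route; a lower number here means less inhibition, a higher number more inhibition at the dose given (going by the name of the read-out). Compound 1 `COc1ccc(-c2nnc(SCC(=O)Nc3ccc(/C(C)=N/O)cc3)n2-c2ccccc2)cc1` gives 45%, and the step of a number 12 percentage points lower from compound 3 to compound 1 (beyond the scatter) comes from hydrogen in place of methoxy on an aromatic carbon. Compound 2 `CCn1c(SCC(=O)Nc2ccc(/C(C)=N/O)cc2)nnc1-c1ccc(OC)cc1` gives 54%; its step from compound 1 is a number 9 percentage points higher from compound 1 to compound 2 (within the scatter). The difference between the core of compound 2 and the core of compound 3 is not broken down here.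

Compound 4 `CCn1c(SCC(=O)Nc2ccc(/C(C)=N/O)cc2)nnc1-c1ccccc1` has not yet been measured in this assay. It differs from compound 2 by hydrogen in place of methoxy on an aromatic carbon. Within the data shown here, this is the same kind of change as the one from compound 3 to compound 1, though not the same: there the leaving methoxy stood ortho to a methoxy group and meta to a large group, here it stands para to a large group, and the two cores differ as well.

The step from compound 2 to compound 4 is expected to be a number 8 percentage points lower from compound 2 to compound 4 (within the scatter), smaller than the earlier step, because the measured a number 12 percentage points lower from compound 3 to compound 1 (beyond the scatter) was only modest and the surroundings of the change are not the same. Compound 4 is therefore estimated at 46%, between 30% and 60%.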

Compound 4, a percentage reported as inhibition, in the whole organism at one dose (the size of the read-out at that dose, not a potency): 54%
The estimate for compound 4 lay 8 percentage points below the measured number; the range from low to high includes it.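

In this assay, hydrogen in place of methoxy on the core of compound 2 gives no change at the digits printed from compound 2 to compound 4 (within the scatter). Set beside the same kind of change on the other core, the two steps do not separate: the same change on two cores in this assay, a number 12 percentage points lower (beyond the scatter) from compound 3 to compound 1 and no change at the digits printed (within the scatter) from compound 2 to compound 4, 12 percentage points apart, within the scatter of two such steps This shows no measurable dependence of the change on the core, but it does not show that the change carries over with a fixed size, since only two steps are available and compound 1 keeps a methoxy group on that ring while compound 4 keeps none.

The compounds shown leave open what a different group at that place on the ring, such as a chlorine or an amine, would do to the inhibition of paw edema. They also leave open whether a propyl chain on the aromatic nitrogen would read any differently from the ethyl of compound 2 and compound 4.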